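Fluorinated aryl variations at the acylurea end of the series

A few compounds are considered here, and "the series" means these few. Any claim that something is new, unique, unknown or untested is made for them only; others in the source may bear on it.

Compounds 1, 2 and 3 share one core and differ only in the aryl group on the carbonyl carbon of the acylurea. Compound 1 `CN(C(=O)NC(=O)c1ccccc1F)c1nc(C(F)(F)F)c(C(=O)N/N=C/c2cc(C(F)(F)F)cc(C(F)(F)F)c2)s1` gives 4.23 ug/mL in a functional assay on BCG823 cells (Homo sapiens) for inhibition, read by MTT assay, with a stated time of 72 h; a lower number here means a stronger inhibitor, a higher number a weaker inhibitor. Compound 2 `CN(C(=O)NC(=O)c1ccc(F)c(F)c1)c1nc(C(F)(F)F)c(C(=O)N/N=C/c2cc(C(F)(F)F)cc(C(F)(F)F)c2)s1` gives 3.51 ug/mL in this assay, and compound 3 `CN(C(=O)NC(=O)c1cccc(C(F)(F)F)c1)c1nc(C(F)(F)F)c(C(=O)N/N=C/c2cc(C(F)(F)F)cc(C(F)(F)F)c2)s1` gives 5.23 ug/mL in this assay. Compound 3 holds the highest of the three numbers, but all three lie within the usual scatter of each other: a 1.2-fold higher number from compound 1 to compound 3 (0.09 log units; within the scatter), and a 1.5-fold higher number from compound 2 to compound 3 (0.17 log units; within the scatter).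

Compound 4 `CN(C(=O)NC(=O)c1c(F)cccc1F)c1nc(C(F)(F)F)c(C(=O)N/N=C/c2cc(C(F)(F)F)cc(C(F)(F)F)c2)s1` is not yet measured. Its change from compound 3 is 2,6-difluorophenyl in place of 3-(trifluoromethyl)phenyl on a carbonyl carbon. Going by the values given here, the steps that bear on it are those that swap one fluorinated aryl group for another on the same carbonyl carbon: a 1.2-fold lower number from compound 1 to compound 2 (0.08 log units; within the scatter), a 1.2-fold higher number from compound 1 to compound 3 (0.09 log units; within the scatter) and a 1.5-fold higher number from compound 2 to compound 3 (0.17 log units; within the scatter). None of them left the scatter, so no step beyond the scatter is expected here either, in either direction. The expected step from compound 3 to compound 4 is a 1.2-fold lower number from compound 3 to compound 4 (0.09 log units; within the scatter). Compound 4 is therefore estimated at 4.3 ug/mL in this assay, with a range from 2.5 ug/mL to 7.5 ug/mL.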

Compound 4, half-maximal inhibitory concentration: 5.28 ug/mL
For compound 4 the middle estimate is 1.2-fold (0.09 log units) below the measured one; low and high end bracket the measured number.
By their numbers in this assay, from the lowest: compounds 2, 1, 3 and 4 (each within the scatter of the next).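

Compound 4 extends the run of fluorinated aryl groups on this carbonyl carbon without leaving the scatter in this assay, with a 1.0-fold higher number from compound 3 to compound 4 (0.00 log units; within the scatter) and with a 1.5-fold higher number from compound 2 to compound 4 (0.18 log units; within the scatter) as its steps from the other aryl groups. The series also gains its smallest structural change here, fluoro in place of hydrogen on an aromatic carbon, and that change gives a 1.2-fold higher number from compound 1 to compound 4 (0.10 log units; within the scatter) as its step. No measured evidence accounts for these numbers.

From the compounds shown here alone, all four aryl groups carry fluorine, so what a phenyl without fluorine, or a phenyl bearing an amine or a carboxylic acid, would do on this carbonyl carbon stays open. The four compounds share everything else, so they cannot tell whether changes elsewhere in the shared core would move the number further.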